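Methyl in place of cyano on the benzyl group

The source may report more compounds than this note shows. Statements on the series, on what has been measured and on what is new or still open speak of the compounds shown alone.

Three compounds sharing one core were tested in an assay for inhibition of high affinity nerve growth factor receptor (Homo sapiens), read by HTRF, with a stated time of 30 min, in the presence of a further agent that is not named here; a higher number here means a weaker inhibitor, a lower number a stronger inhibitor. Compound 1 `Cc1cc(Nc2nc(NCc3ccc(Cl)cc3)nc3ccccc23)n[nH]1` gives 380 nM, compound 2 `Cc1cc(Nc2nc(NCc3ccc(Br)cc3)nc3ccccc23)n[nH]1` gives 180 nM, and compound 3 `Cc1cc(Nc2nc(NCc3ccc(C#N)cc3)nc3ccccc23)n[nH]1` gives 83 nM, the lowest of the three numbers. The steps of a 2.1-fold lower number from compound 1 to compound 2 (0.32 log units; beyond the scatter), a 4.6-fold lower number from compound 1 to compound 3 (0.66 log units; beyond the scatter) and a 2.2-fold lower number from compound 2 to compound 3 (0.34 log units; beyond the scatter) place the cyano-bearing compound 3 ahead of both halogen analogues. Compound 4 `Cc1ccc(CNc2nc(Nc3cc(C)[nH]n3)c3ccccc3n2)cc1` differs from compound 3 by methyl in place of cyano on an aromatic carbon. Among the measured compounds shown here, no measured step covers methyl directly, so the expectation rests on the halogen compounds, both of which sit behind compound 3. A modest rise in this assay is therefore expected, a 3.0-fold higher number from compound 3 to compound 4 (0.48 log units; beyond the scatter), landing near the halogen analogues. Compound 4 is expected to give 250 nM, within a range from 100 nM to 700 nM.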

Compound 4, half-maximal inhibitory concentration: 110 nM
For compound 4 the middle estimate is 2.3-fold (0.36 log units) above the measured one; the measured number falls inside the stated range.
By their numbers in this assay, from the lowest: compounds 3, 4 and 2 (each within the scatter of the next, the first and the last beyond it); then compound 1.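

In this assay the change gives a 1.3-fold higher number from compound 3 to compound 4 (0.12 log units; within the scatter) and so shows that cyano is not needed at this position for a number in this range, even though a hydrogen-bond acceptor leaves with it. The same methyl gives a 1.6-fold lower number from compound 2 to compound 4 (0.21 log units; within the scatter) against bromo and a 3.5-fold lower number from compound 1 to compound 4 (0.54 log units; beyond the scatter) against chloro, so only chloro stands clearly apart from methyl here.

Whether an amine, a methoxy group or a longer chain such as ethyl would fit this position remains open, and no measured evidence accounts for these results.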